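Para substituent step from compound 3 to compound 4

The compounds below may be only part of what the source reports. "The series", "measured", "known", "first", "only" and "open" are said of these compounds alone.

Values in a functional assay on brain (Rattus norvegicus, strain Wistar) for inhibition; a higher number here means a weaker inhibitor, a lower number a stronger inhibitor:
- compound 1 `Cc1[nH]c(=O)n(C)c1-c1ccccc1`: > 100000 nM, a limit of the assay and not a number
- compound 2 `CCCCc1ccc(-c2c(C)[nH]c(=O)n2C(C)C)cc1`: 10700 nM
- compound 3 `Cc1ccc(-c2c(C)[nH]c(=O)n2C)cc1`: 85300 nM

In this assay compound 3 at 85300 nM has the higher of the two actual numbers. The other number belongs to compound 2 at 10700 nM, which is clearly lower, but compound 2 differs from compound 3 in more than one place.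

The next structure is compound 4 `Cc1[nH]c(=O)n(C)c1-c1ccc(OC(C)C)cc1`. The change is isopropoxy in place of methyl on an aromatic carbon, para to a group of 8 heavy atoms (isopropoxy in place of methyl on an aromatic carbon).

Among the measured compounds shown here, only one measured step involves a change on an aromatic carbon: an at least 1.1-fold lower number from compound 1 to compound 3 (0.06 log units; that floor lies within the scatter). It rests on (the limit of > 100000 nM in this assay, at which 1 of the 3 values shown sits), so it fixes no size and offers only weak guidance. The expectation of a lower number rests mainly on compound 2 at 10700 nM, and that comparison is not a clean one. A modest move is therefore expected, estimated as a 2.1-fold lower number from compound 3 to compound 4 (0.33 log units; beyond the scatter). For compound 4 the estimated value is 40000 nM, with an expected range of 12000 nM to 100000 nM.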

Compound 4, half-maximal inhibitory concentration: 20400 nM
The estimate for compound 4 lay 2.0-fold (0.29 log units) above the measured number; low and high end bracket the measured number.
By their numbers in this assay, from the lowest: compounds 2 and 4 (each within the scatter of the next); then compound 3. At a limit, above all of these: compound 1.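

In this assay, the aromatic carbon para to a group of 8 heavy atoms now shows a step of measurable size beyond the scatter: a 4.2-fold lower number from compound 3 to compound 4 (0.62 log units; beyond the scatter), with isopropoxy in place of methyl. This change enlarges the group from 1 heavy atom to 4 and brings in 1 hydrogen-bond acceptor, so this position accepts a branched ether without loss in this series, and the number falls. Compound 1 stands at > 100000 nM, a limit of the assay and not a number, so the comparison with hydrogen gives only a floor, now beyond the scatter where the earlier floor lay within it, as an at least 4.9-fold lower number from compound 1 to compound 4 (0.69 log units; beyond the scatter) rests on a limit: the limit of > 100000 nM in this assay, at which 1 of the 4 values shown sits.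

The two changes in the group remain tied together here, so the step cannot be assigned to the oxygen or to the added carbon atoms; a methoxy group and a propyl group at the same carbon would separate them. Going by these compounds, how an amine, a carboxylic acid or a longer alkoxy chain at this carbon would read in this assay also stays open.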